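Carbamate cap exchange and cell tolerance in the series

This account rests on a few compounds, and the source may have more. Where it says the series, first, only, none or still open, it means among the compounds named here.

Within the data shown here, compound 1 `CCCC[C@H]1CC[C@H](OC(=O)N[C@@H](CC(C)C)C(=O)N[C@@H](C[C@@H]2CCNC2=O)C(O)S(=O)(=O)O)CC1` is the only member of the series with a number in an ADME assay on HEK-293T cells (Homo sapiens) for cytotoxicity, with a stated time of 72 h (a higher number here means that more compound is tolerated, a lower number that less compound is tolerated), where compound 1 gives 58000 nM. Compound 2 `CCC[C@H]1CC[C@H](COC(=O)N[C@@H](CC(C)C)C(=O)N[C@@H](C[C@@H]2CCNC2=O)C(O)S(=O)(=O)O)CC1` gives 44000 nM; "not determined" (no result reported) (2 entries) in this assay. The several entries of compound 2 in this assay are the several entries of compound 2 in this assay, 44000 nM; "not determined" (no result reported) (2 entries). Compound 3 `CC(C)C[C@H](NC(=O)OCC1CCC(F)(F)CC1)C(=O)N[C@@H](C[C@@H]1CCNC1=O)C(O)S(=O)(=O)O` gives "not determined" (no result reported); "not determined" (no result reported) (2 entries) in this assay, so no number is available for compound 3. Compound 4 `CC(C)C[C@H](NC(=O)OCc1cccc(F)c1)C(=O)N[C@@H](C[C@@H]1CCNC1=O)C(O)S(=O)(=O)O` is the next step from compound 1, with 3-fluorobenzyl in place of 4-butylcyclohexyl on an oxygen next to a carbonyl group. Among the measured compounds shown here, no step between measured compounds in this assay is available, so no direction is established; the expectation is a change no larger than the usual scatter, a 1.0-fold higher number from compound 1 to compound 4 (0.01 log units; within the scatter). Compound 4 is therefore estimated at 60000 nM in this assay, with a range from 25000 nM to 150000 nM expected.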

Compound 4, half-maximal cytotoxic concentration: > 100000 nM
Compound 4 ended at the assay's limit (the forecaster's own chance of this, stated with the estimate: 35%); middle value at least 1.6-fold (0.22 log units) away from the limit.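

In this assay, 3-fluorobenzyl in place of 4-butylcyclohexyl on an oxygen next to a carbonyl group gives an at least 1.7-fold higher number from compound 1 to compound 4 (0.23 log units; that floor lies within the scatter). Compound 4 gives > 100000 nM, a limit of the assay and not a number: the limit of > 100000 nM in this assay, at which 1 of the 4 values shown sits. Among these compounds, this is the first readable step at this position, and it shows that the aromatic ring is tolerated there without a fall in the number, though only a floor of the step can be read.

Open, from the compounds shown here alone, is the true size of this step, and whether benzyl without fluorine or a cap carrying an amine would reach the same limit.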